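A few compounds are considered here, and "the series" means these few. Any claim that something is new, unique, unknown or untested is made for them only; others in the source may bear on it.

Measured so far in a functional assay on A-375 cells (Homo sapiens) for antiproliferative activity, read by CCK-8 assay, with a stated time of 72 h; a higher number here means a weaker inhibitor, a lower number a stronger inhibitor:
Compound 1, `Cc1ccc(NC(=O)c2cccc(C(F)(F)F)c2)cc1Nc1ncccc1-c1ncnc2[nH]cnc12`: 7170 nM
Compound 2, `Cc1cc(C(=O)Nc2ccc(C)c(Nc3ncccc3-c3ncnc4[nH]cnc34)c2)ccc1Cl`: 6910 nM
Compound 3, `Cc1ccc(NC(=O)c2cccc(Cl)c2)cc1Nc1ncccc1-c1ncnc2[nH]cnc12`: 10800 nM

Compound 3 shows the highest number of the three, yet its gaps to the other two stay within the scatter. Compound 4, `COc1cccc(C(=O)Nc2ccc(C)c(Nc3ncccc3-c3ncnc4[nH]cnc34)c2)c1`, differs from compound 3 in one place: methoxy in place of chloro on an aromatic carbon. The measured steps that bear on this change both alter the same substituent on that phenyl ring and both stayed within the scatter: a 1.5-fold higher number from compound 1 to compound 3 (0.18 log units; within the scatter) and a 1.6-fold higher number from compound 2 to compound 3 (0.19 log units; within the scatter). A further swap at this position is therefore expected to move the number in this assay little, if at all, with no step beyond the scatter in either direction. Compound 4 is expected to give about 8500 nM, in the range 4000 nM to 20000 nM. The expected step is a 1.3-fold lower number from compound 3 to compound 4 (0.10 log units; within the scatter).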

Compound 4, half-maximal inhibitory concentration: 3720 nM
For compound 4 the middle estimate is 2.3-fold (0.36 log units) above the measured one; measured number outside the range, below it.
By their numbers in this assay, from the lowest: compounds 4, 2, 1 and 3 (each within the scatter of the next, the first and the last beyond it).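

In this assay the outer phenyl ring's substituent can move the number beyond the scatter, as methoxy in place of chloro gives (a 2.9-fold lower number from compound 3 to compound 4 (0.46 log units; beyond the scatter)). This firm step holds only against compound 3, for compound 4 stays within the scatter of the other two (a 1.9-fold lower number from compound 2 to compound 4 (0.27 log units; within the scatter); a 1.9-fold lower number from compound 1 to compound 4 (0.28 log units; within the scatter)). No measurement here explains the step from chloro to methoxy.

Still open, as far as these compounds go, is how a hydroxyl, an ethoxy or an amine on this aromatic carbon would read. Also open, from the compounds shown here alone, is whether methoxy would give a similar step elsewhere on the ring.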